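A few compounds are considered here, and "the series" means these few. Any claim that something is new, unique, unknown or untested is made for them only; others in the source may bear on it.

Working notes on the series. Three compounds sharing one core have been run in a functional assay on the whole organism with Rattus norvegicus as the target, at a dose of 20 mg/kg by the oral route; on this read-out lower numbers stand for less inhibition and higher numbers for more inhibition at the one dose given (going by the name of the read-out). Compound 1 `O=C(/C=C1\CCc2ccc(F)cc21)NCC1CC1` gives 21%; compound 2 `CC(C)NC(=O)/C=C1\CCc2ccc(F)cc21` gives 71%; compound 3 `O=C(/C=C1\CCc2ccc(F)cc21)NC1CCC1` gives 0%. Among the three, compound 3 stands lowest, with a number 21 percentage points lower from compound 1 to compound 3 (beyond the scatter) and a number 71 percentage points lower from compound 2 to compound 3 (beyond the scatter). Going by the values given here, the one further step, a number 50 percentage points higher from compound 1 to compound 2 (beyond the scatter), shows how strongly the read-out moves when only the group on the amide-type nitrogen changes.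

Compound 4 `CON(C)C(=O)/C=C1\CCc2ccc(F)cc21` is not yet measured. The change from compound 3 is methoxy(methyl)amino in place of cyclobutylamino on a carbonyl carbon. Among the compounds with values here, none of the measured steps covers this kind of change: each of them swaps one carbon group for another on the amide-type nitrogen and keeps the hydrogen-bond donor, whereas here the donor leaves and an acceptor enters, and the ring is lost. The measured steps only show that the read-out in this assay is sensitive to what sits at this position, with steps ranging from modest to large. Since compound 3 sits at the floor of the scale, the step to compound 4 can hardly go downward; an upward step is possible but unsupported by any direct precedent.

Compound 4 is therefore expected to give about 15%, with a range from 0% to 50%. This estimate implies a number 15 percentage points higher from compound 3 to compound 4 (beyond the scatter), a step that may or may not exceed the scatter.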

Compound 4, a percentage reported as inhibition, in the whole organism at one dose (the size of the read-out at that dose, not a potency): 14%
Beside the measured number, compound 4's estimate is 1 percentage points above it; the range from low to high includes it.
By their numbers in this assay, from the lowest: compound 3; then compounds 4 and 1 (each within the scatter of the next); then compound 2.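

In this assay, methoxy(methyl)amino on the carbonyl carbon brings a number a number 14 percentage points higher from compound 3 to compound 4 (beyond the scatter) and shows that this position can carry a group with no hydrogen-bond donor and no ring and still give a read-out off the floor of the scale. Set against the two other amides, the same change gives a number 7 percentage points lower from compound 1 to compound 4 (within the scatter) and a number 57 percentage points lower from compound 2 to compound 4 (beyond the scatter) so compound 4 cannot be told apart from compound 1 while compound 2 remains clearly separate, and the presence of a hydrogen-bond donor does not by itself sort these compounds, since compound 2 and compound 3 both carry one and lie furthest apart. No measurement at hand gives a reason for any of these steps.

The compounds shown leave open which part of methoxy(methyl)amino goes with the step, a question that a dimethylamino or a methoxyamino group on the carbonyl carbon would address. They also leave open whether the read-out of compound 2 at 71% is kept with a tert-butylamino or an ethylamino group at this place.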